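The compounds below may be only part of what the source reports. "The series", "measured", "known", "first", "only" and "open" are said of these compounds alone.

Of the compounds shown here, three built on one shared core have been tested in a functional assay on GLC82 cells (Homo sapiens) for cytotoxicity, read by MTT assay, with a stated time of 72 h; on this read-out higher numbers stand for weaker inhibition and lower numbers for stronger inhibition. Compound 1 `O=C(NC(=S)NNc1ncnc2ccccc12)c1ccc(C(F)(F)F)cc1` gives 12200 nM. Compound 2 `COc1cc2ncnc(NNC(=S)NC(=O)c3ccc(F)cc3)c2cc1OC` gives 15300 nM. Compound 3 `Cc1ccc(C(=O)NC(=S)NNc2ncnc3ccccc23)cc1` gives 11200 nM, the lowest of the three numbers, though its gaps to compound 1 and to compound 2 both fall within the scatter, so no ordering can be read from them. Among the compounds with values here, the only measured pair that differs in one place is the exchange of methyl in place of trifluoromethyl on an aromatic carbon: a 1.1-fold lower number from compound 1 to compound 3 (0.04 log units; within the scatter).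

Compound 4 `O=C(NC(=S)NNc1ncnc2ccccc12)c1cccc(Cl)c1` has not yet been measured. Relative to compound 3 it differs in one place: 3-chlorophenyl in place of 4-methylphenyl on a carbonyl carbon. Within the data shown here, the measured step bears on this only loosely, since it too swapped one small group on that aromatic ring for another and produced a change within the scatter, but no measured pair tests a 3-chlorophenyl group. On that basis the expected step in this assay is a 1.1-fold higher number from compound 3 to compound 4 (0.03 log units; within the scatter), nothing beyond the scatter. Compound 4 is therefore estimated at 12000 nM in this assay, with a range from 5000 nM to 30000 nM.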

Compound 4, half-maximal inhibitory concentration: 3240 nM
Estimate against measurement, compound 4: 3.7-fold (0.57 log units) above; the measured number lies below the stated range.
By their numbers in this assay, from the lowest: compound 4; then compounds 3, 1 and 2 (each within the scatter of the next).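

In this assay, the aromatic group on the carbonyl carbon proves able to shift the result: placing 3-chlorophenyl there instead of 4-methylphenyl gives a 3.5-fold lower number from compound 3 to compound 4 (0.54 log units; beyond the scatter), a modest step beyond the scatter towards stronger inhibition. The earlier exchange of methyl in place of trifluoromethyl, a 1.1-fold lower number from compound 1 to compound 3 (0.04 log units; within the scatter), stayed within the scatter, so only now is there a sign that changes to this aromatic group can matter, even though the two groups in the new step carry the same number of heavy atoms and neither has hydrogen-bond donors or acceptors. Nothing measured here explains why this exchange lowers the number.

On these data alone, the step alters both the substituent and its numbered place on the ring, so it remains open whether the chlorine or its placement matters, which a 4-chlorophenyl or a 3-methylphenyl group on the same carbonyl carbon could help separate. Also open, as far as these compounds go, are whether a different group on the ring, such as an amine or a methoxy, would go further, and whether 3-chlorophenyl would lower the number on the core of compound 2 as well.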